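The source may report more compounds than this note shows. Statements on the series, on what has been measured and on what is new or still open speak of the compounds shown alone.

In an ADME assay on L6 cells (Rattus norvegicus) for cytotoxicity, read by resazurin assay, with a stated time of 70 h (on this read-out lower numbers stand for stronger inhibition and higher numbers for weaker inhibition), compound 3 (`CC(=O)Oc1ccc2c(c1)C(C)=CC(C)(C)N2Cc1ccc(C#N)cc1`) gives 29000 nM. Within the data shown here, that number cannot be told apart from the one for compound 2 (`CC(=O)Oc1ccc2c(c1)C(C)=CC(C)(C)N2Cc1ccccc1`), which gives 24000 nM. Compound 1 (`CC1=CC(C)(C)N(Cc2ccc(Cl)cc2)c2ccc(O)cc21`) gives 7900 nM, a lower number than compound 3, and that gap lies beyond the scatter.

Compound 4 (`CC(=O)Oc1ccc2c(c1)C(C)=CC(C)(C)N2Cc1ccc(Cl)cc1`) differs from compound 3 in one place: chloro in place of cyano on an aromatic carbon. Put differently, the 4-cyanophenyl of compound 3 gives way to 4-chlorophenyl in compound 4.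

Among the measured compounds shown here, no measured step makes this exact swap. The closest evidence is a 1.2-fold higher number from compound 2 to compound 3 (0.08 log units; within the scatter), which puts cyano in place of hydrogen at a cost within the scatter. Removing the cyano group therefore made no clear difference in that pair, and a small step seems likely here as well. Compound 1, at 7900 nM, also carries 4-chlorophenyl, but it differs from compound 4 elsewhere, so it is only a loose hint toward a somewhat lower number.

The expected change, which should stay within the scatter, is a 1.5-fold lower number from compound 3 to compound 4 (0.16 log units; within the scatter). For compound 4, the estimated value is 20000 nM, with an expected range of 10000 nM to 36000 nM.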

Compound 4, half-maximal inhibitory concentration: 22000 nM
For compound 4 the middle estimate is 1.1-fold (0.04 log units) below the measured one; low and high end bracket the measured number.
By their numbers in this assay, from the lowest: compound 1; then compounds 4, 2 and 3 (each within the scatter of the next).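

At this aromatic carbon, three different substituents on the shared core can now be compared in this assay. The step of a 1.3-fold lower number from compound 3 to compound 4 (0.12 log units; within the scatter) and the step of a 1.1-fold lower number from compound 2 to compound 4 (0.04 log units; within the scatter) show that chloro reads the same as both cyano and hydrogen, so the earlier flat step from hydrogen to cyano now extends to a second group. Compound 4 also isolates a different place, with 4-chlorophenyl held constant: a 2.8-fold higher number from compound 1 to compound 4 (0.44 log units; beyond the scatter) shows that having acetyl rather than hydrogen on the oxygen goes with a higher number, which ties the gap seen for compound 1 to that single change, though no measurement shown here explains either result.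

The compounds shown place only hydrogen, cyano and chloro at this carbon, so it remains open whether a very different group there, such as an amine, a carboxylic acid or a longer chain, would also leave the number unmoved. As far as these compounds go, the hydrogen-on-oxygen comparison rests on 4-chlorophenyl alone, so it also remains open whether the same step would appear with cyano or hydrogen at this carbon.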